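Replacing the Dichlorophenyl Amide with a Propyl Chain

The source may hold more compounds than are shown below. What is called first, only, known or untested is meant among the compounds shown, and "the series" means these compounds.

Compound 3 `COc1cc(/C=C/C(=O)c2cccc(NC(=O)c3ccc(Cl)cc3Cl)c2)ccc1O` carries a 2,4-dichlorophenyl group on the carbonyl carbon of its amide. In a functional assay on HUVEC cells (Homo sapiens) for inhibition, tested at 10 ug/mL (a lower number here means a weaker effect, a higher number a stronger effect of the compound at the concentration tested), compound 3 gives 70%, the lowest of the three values shown. Compound 1 `COc1cc(/C=C/C(=O)c2cccc(NC(=O)c3c(Cl)cccc3Cl)c2)ccc1O` gives 99% in this assay, and compound 2 `COc1cc(/C=C/C(=O)c2cccc(NC(=O)c3cccs3)c2)ccc1O` gives 90%. The step of a number 29 percentage points lower from compound 1 to compound 3 (beyond the scatter) and the step of a number 20 percentage points lower from compound 2 to compound 3 (beyond the scatter) are both beyond the scatter, whereas the step of a number 9 percentage points lower from compound 1 to compound 2 (within the scatter) is within it.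

Compound 4 `CCCC(=O)Nc1cccc(C(=O)/C=C/c2ccc(O)c(OC)c2)c1` differs from compound 3 in one place: propyl in place of 2,4-dichlorophenyl on a carbonyl carbon. None of the three measured steps exchanges a ring for a chain at this carbonyl carbon; all of them compare one ring with another, so they bear on the change only loosely. They do show that this position shifts the read-out by modest amounts, as in a number 29 percentage points lower from compound 1 to compound 3 (beyond the scatter). With no measured chain to lean on, a modest step in either direction is plausible, and a somewhat lower value is expected because the shown steps reached compound 3 only from above, as in a number 20 percentage points lower from compound 2 to compound 3 (beyond the scatter).

Compound 4 is therefore expected to give about 62% in this assay, within a wide range from 30% to 90%. This estimate means a step of a number 8 percentage points lower from compound 3 to compound 4 (within the scatter), expected to lie within the scatter.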

Compound 4, a percentage reported as inhibition, at one concentration (the size of the read-out at that concentration, not a potency): 87%
Estimate against measurement, compound 4: 25 percentage points below; the measured number falls inside the stated range.
By their numbers in this assay, from the lowest: compound 3; then compounds 4, 2 and 1 (each within the scatter of the next, the first and the last beyond it).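

The propyl chain shows that a ring on this carbonyl carbon is not needed for a strong read-out in this assay: removing the 2,4-dichlorophenyl group gives a number 17 percentage points higher from compound 3 to compound 4 (beyond the scatter). Ring against chain does not sort these compounds, since the change gives a number 12 percentage points lower from compound 1 to compound 4 (beyond the scatter) when the ring left behind is 2,6-dichlorophenyl, while the change from thiophen-2-yl gives a number 3 percentage points lower from compound 2 to compound 4 (within the scatter). The chain thus falls among the ring groups, and the data shown say more about which ring is present than about whether one is present at all, although no measurement offered here accounts for these differences.

On these data alone, whether a butyl or longer chain would hold the read-out remains open, as does the effect of an amine or a carboxylic acid at the chain's end. Each read-out is also a single-concentration figure, so the potency of these compounds remains unknown.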